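This account rests on a few compounds, and the source may have more. Where it says the series, first, only, none or still open, it means among the compounds named here.

Among the measured compounds shown here, compound 3 `COc1ccc(NC(=O)c2cc([N+](=O)[O-])ccc2Oc2ccc(OC)cc2)cc1` gives 3400 nM in a functional assay (Homo sapiens) for inhibition, using a membrane potential dye, in the presence of a further agent that is not named here (a lower number here means a stronger inhibitor, a higher number a weaker inhibitor), the lowest of the three numbers measured so far. Compound 2 `COc1ccc(Oc2ccc([N+](=O)[O-])cc2C(=O)Nc2ccc(F)cc2)cc1` gives 7200 nM, and compound 1 `CCN(C(=O)c1cc([N+](=O)[O-])ccc1Oc1ccc(OC)cc1)c1ccc(Cl)cc1` gives 8300 nM. The step of a 2.1-fold lower number from compound 2 to compound 3 (0.33 log units; beyond the scatter) and the step of a 2.4-fold lower number from compound 1 to compound 3 (0.39 log units; beyond the scatter) are both modest, while the step of a 1.2-fold lower number from compound 1 to compound 2 (0.06 log units; within the scatter) stays within the scatter. Compound 4 `COc1ccc(Oc2ccc([N+](=O)[O-])cc2C(=O)Nc2ccc(C(C)=O)cc2)cc1` differs from compound 3 by acetyl in place of methoxy on an aromatic carbon. For the measured compounds named here, only the step from compound 2 to compound 3 exchanges the same group, and it was modest; no measured step exchanges methoxy for acetyl. A small shift in either direction, or none beyond the scatter, is therefore expected. For compound 4 the expected step is a 1.3-fold higher number from compound 3 to compound 4 (0.12 log units; within the scatter). In this assay compound 4 is estimated at 4500 nM, with a range from 1800 nM to 11000 nM.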

Compound 4, half-maximal inhibitory concentration: 8100 nM
Estimate against measurement, compound 4: 1.8-fold (0.26 log units) below; low and high end bracket the measured number.
By their numbers in this assay, from the lowest: compound 3; then compounds 2, 4 and 1 (each within the scatter of the next).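

With acetyl in place of methoxy, this assay shows a 2.4-fold higher number from compound 3 to compound 4 (0.38 log units; beyond the scatter), so the advantage seen with methoxy over fluoro does not extend to acetyl at this place. Acetyl and fluoro cannot be told apart, with a 1.1-fold higher number from compound 2 to compound 4 (0.05 log units; within the scatter), and the (4-acetylphenyl)amino group likewise stays level with (4-chlorophenyl)(ethyl)amino, with a 1.0-fold lower number from compound 1 to compound 4 (0.01 log units; within the scatter). No available evidence accounts for methoxy standing apart from acetyl and fluoro. Going by these compounds, whether an amine, a hydroxyl or an ethoxy group at this place would read with methoxy or with acetyl and fluoro remains open.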